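A Methyl on the Oxygen: Compound 4 Estimated

The source may hold more compounds than are shown below. What is called first, only, known or untested is meant among the compounds shown, and "the series" means these compounds.

Compound 1 `CC1(/C=C/c2ccccc2O)C=CC(=O)O1`: > 1000000 nM
Compound 2 `CC1(/C=C/c2cccc(O)c2)C=CC(=O)O1`: > 1000000 nM
Compound 3 `COc1ccccc1/C=C/C1(C)C=CC(=O)O1`: 860000 nM

In a functional assay on K562 cells (Homo sapiens) for inhibition, read by sulforhodamine B assay, with a stated time of 48 h (on this read-out higher numbers stand for weaker inhibition of growth and lower numbers for stronger inhibition of growth), compound 1 reaches only a limit, > 1000000 nM. Compound 2 likewise shows only a limit, > 1000000 nM. The difference between the cores of compound 1 and compound 2 is not broken down here. Compound 3 gives a number, 860000 nM. The change methyl in place of hydrogen on an oxygen on an aromatic ring made a step of an at least 1.1-fold lower number from compound 1 to compound 3 (0.06 log units; that floor lies within the scatter), against (the limit of > 1000000 nM in this assay, at which 2 of the 3 values shown sit). Compound 4 `COc1cccc(/C=C/C2(C)C=CC(=O)O2)c1` carries the same change, (methyl in place of hydrogen on an oxygen on an aromatic ring), at the same place. The step expected from compound 2 to compound 4 is an at least 1.1-fold lower number from compound 2 to compound 4 (0.04 log units; that floor lies within the scatter), resting on the step of an at least 1.1-fold lower number from compound 1 to compound 3 (0.06 log units; that floor lies within the scatter). Compound 4 is expected to give about 900000 nM, estimated between 400000 nM and 3000000 nM.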

Compound 4, concentration for total growth inhibition: > 1000000 nM
Compound 4: a limit, no number; the forecaster's own chance of this, stated with the estimate: 55%; middle value at least 1.1-fold (0.04 log units) away from the limit.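

Compound 2 and compound 4 both stop at a limit rather than a number, so no step between them can be read: the limit of > 1000000 nM in this assay, at which 3 of the 4 values shown sit.

The compounds shown leave open whether hydroxy to methoxy changes growth inhibition from compound 2 to compound 4 in this assay at all.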